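The source may report more compounds than this note shows. Statements on the series, on what has been measured and on what is new or still open speak of the compounds shown alone.

Measured in an ADME assay (liver) for metabolic stability, with Liver microsome (Homo sapiens) as the target, using microsomes and NADPH, with a stated time of 30 min, tested at 1 uM; on this read-out higher numbers stand for fast clearance and lower numbers for slow clearance:
Compound 1 `COCC#Cc1cc(C(O)(C(F)(F)F)C(F)(F)F)cnc1N1CCN(S(=O)(=O)c2ccc(N)nc2)CC1`: 15 mL.min-1.g-1
Compound 2 `Nc1ccc(S(=O)(=O)N2CCN(c3ncc(C(O)(C(F)(F)F)C(F)(F)F)cc3C#CCCO)CC2)cn1`: < 14 mL.min-1.g-1 (a limit of the assay, not a number)

Compound 2 has no exact number and sits at the limit of < 14 mL.min-1.g-1 in this assay, at which 1 of the 2 values shown sits. The next structure, compound 3 `CC(C)n1cc(-c2cc(C(O)(C(F)(F)F)C(F)(F)F)cnc2N2CCN(S(=O)(=O)c3ccc(N)nc3)CC2)cn1`, differs from it at one place (1-isopropyl-1H-pyrazol-4-yl in place of 4-hydroxybut-1-yn-1-yl on an aromatic carbon). Here 1-isopropyl-1H-pyrazol-4-yl stands in place of 4-hydroxybut-1-yn-1-yl on an aromatic carbon.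

Going by the values given here, only one measured step is available, an at least 1.0-fold lower number from compound 1 to compound 2 (0.02 log units; that floor lies within the scatter). It put hydroxymethyl in place of methoxy on a saturated chain carbon bound to a triple-bonded carbon, and it lies within the scatter. That step changes only the end of the chain and keeps the triple bond, so it bears only weakly on replacing the whole group. Among the compounds with values here, no measured compound carries a pyrazole. The nearest number is that of compound 1, at 15 mL.min-1.g-1, so the expectation stays close to it.

A modest rise is expected in this assay, an estimated at least 1.5-fold higher number from compound 2 to compound 3 (0.19 log units; that floor lies within the scatter), and this is uncertain. The estimate for compound 3 is 22 mL.min-1.g-1, with an expected range of 12 mL.min-1.g-1 to 45 mL.min-1.g-1.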

Compound 3, intrinsic clearance in microsomes: 38 mL.min-1.g-1
Compound 3: middle estimate off by 1.7-fold (0.24 log units), on the low side; measured number inside the range.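

In this assay, the earlier change at the end of the chain stayed within the scatter, whereas replacing the whole group on this aromatic carbon moves the read-out clearly, so this position can shift clearance in a way the chain end did not show: 1-isopropyl-1H-pyrazol-4-yl in place of 3-methoxyprop-1-yn-1-yl gives a 2.5-fold higher number from compound 1 to compound 3 (0.40 log units; beyond the scatter). In place of 4-hydroxybut-1-yn-1-yl, the same group gives an at least 2.7-fold higher number from compound 2 to compound 3 (0.43 log units; beyond the scatter). That second step is only a floor on the true size of the change, because compound 2 has a limit of the assay rather than a number: the limit of < 14 mL.min-1.g-1 in this assay, at which 1 of the 3 values shown sits.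

The pyrazole ring and its isopropyl group enter together, and the compounds shown do not tell their contributions apart. Also open, from the compounds shown here alone, is how a smaller 1-methyl-1H-pyrazol-4-yl group, a plain phenyl ring or a nitrile on this aromatic carbon would read in this assay, and so whether the higher number belongs to the isopropyl group, to the ring or simply to the loss of the triple bond.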